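The compounds below may be only part of what the source reports. "The series", "measured", "known", "first", "only" and "open" are said of these compounds alone.

Three compounds share one core and differ only in the group on an oxygen on an aromatic ring. Compound 1 `CCCCOc1cc(CCc2nc(C)c(CC)s2)nc(NCc2cc(Cl)cc(NC(=O)OC(C)C)c2)c1` gives 16 nM in an assay on cells for binding affinity to Neuropeptide Y receptor type 1 (Homo sapiens); on this read-out lower numbers stand for stronger inhibition and higher numbers for weaker inhibition. Compound 2 `CCc1sc(CCc2cc(OC3CCC3)cc(NCc3cc(Cl)cc(NC(=O)OC(C)C)c3)n2)nc1C` gives 11 nM in this assay, and compound 3 `CCc1sc(CCc2cc(OC3CCCC3)cc(NCc3cc(Cl)cc(NC(=O)OC(C)C)c3)n2)nc1C` gives 11 nM. The steps of a 1.5-fold lower number from compound 1 to compound 2 (0.16 log units; within the scatter) and a 1.5-fold lower number from compound 1 to compound 3 (0.16 log units; within the scatter) are both small, and no change at the digits printed from compound 2 to compound 3 (within the scatter) shows that the larger ring left the number where it was. Compound 3 thus sits level with compound 2 on these numbers. Compound 4 `CCc1sc(CCc2cc(OC3CCOCC3)cc(NCc3cc(Cl)cc(NC(=O)OC(C)C)c3)n2)nc1C` carries the change (oxan-4-yl in place of cyclopentyl on an oxygen on an aromatic ring). Among the compounds with values here, no measured step puts a hetero atom into this ring; the ring-size step no change at the digits printed from compound 2 to compound 3 (within the scatter) is the nearest guide. Compound 4 is therefore expected at 15 nM, range 6 nM to 40 nM. The step of a 1.4-fold higher number from compound 3 to compound 4 (0.13 log units; within the scatter) is expected to stay within the scatter.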

Compound 4, half-maximal inhibitory concentration: 4.4 nM
Compound 4: the middle estimate sits 3.4-fold (0.53 log units) above what was measured; the whole stated range lies above it.
By their numbers in this assay, from the lowest: compound 4; then compounds 2, 3 and 1 (each within the scatter of the next).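

Putting oxan-4-yl on this oxygen gives a step beyond the scatter from each earlier compound: a 2.5-fold lower number from compound 3 to compound 4 (0.40 log units; beyond the scatter), a 2.5-fold lower number from compound 2 to compound 4 (0.40 log units; beyond the scatter) and a 3.6-fold lower number from compound 1 to compound 4 (0.56 log units; beyond the scatter). Butyl, cyclobutyl and cyclopentyl had stayed within the scatter of one another, so only this ring, the one with a hetero atom, shows that the position can respond to a change. No evidence here accounts for this step.

Oxan-4-yl differs from cyclopentyl in both ring size and ring oxygen, so the compounds shown leave open which of the two matters. Cyclohexyl, the six-membered ring of carbon only, would separate them, and piperidin-4-yl, with nitrogen in place of that oxygen, remains open too.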